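The compounds below may be only part of what the source reports. "The series", "measured", "known", "first", "only" and "open" are said of these compounds alone.

Measured in a functional assay on HL-60 cells (Homo sapiens) for cytotoxicity, read by WST assay, with a stated time of 48 h; on this read-out lower numbers stand for an effect already at smaller amounts and higher numbers for an effect only at larger amounts of compound:

- Compound 1 `Cc1ccc(C[C@H]2C(=O)OC[C@@H]2Cc2ccccc2)cc1C`: 35000 nM
- Compound 2 `COc1ccccc1C[C@H]1COC[C@@H]1Cc1ccc(Cl)c(Cl)c1`: 55000 nM
- Compound 3 `Cc1ccccc1C[C@H]1COC[C@@H]1Cc1ccc(Cl)c(Cl)c1`: 21000 nM

Compound 3, at 21000 nM, cannot be told apart from compound 1, at 35000 nM, since the two numbers lie within the usual scatter of each other. For the measured compounds named here, compound 2 is clearly separated from compound 3, and that pair gives the only measured step in this small set. Methyl in place of methoxy on an aromatic carbon gives a 2.6-fold lower number from compound 2 to compound 3 (0.42 log units; beyond the scatter), a modest change.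

The next compound is compound 4 `Cc1ccc(C[C@H]2COC[C@@H]2Cc2ccc(Cl)c(Cl)c2)cc1`, with 4-methylphenyl in place of 2-methylphenyl on a saturated chain carbon bound to a saturated ring carbon. The atoms stay the same and only their joining differs. Going by the values given here, the step to compound 3 swaps one group for another, so it offers only a loose guide to this change, and no measured pair shows such a shift directly. In this assay, no step beyond the scatter is therefore expected. The expected step is a 1.1-fold higher number from compound 3 to compound 4 (0.06 log units; within the scatter). For compound 4 the estimated value is 24000 nM, with an expected range from 10000 nM to 55000 nM.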

Compound 4, half-maximal effective concentration: 21000 nM
Compound 4: the middle estimate sits 1.1-fold (0.06 log units) above what was measured; the measured number falls inside the stated range.
By their numbers in this assay, from the lowest: compounds 3, 4, 1 and 2 (each within the scatter of the next, the first and the last beyond it).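

In this assay, 4-methylphenyl in place of 2-methylphenyl on a saturated chain carbon bound to a saturated ring carbon gives no change at the digits printed from compound 3 to compound 4 (within the scatter). The earlier step, from methoxy to methyl, swapped one group for another, whereas this pair keeps the same atoms and alters only how they are joined, and that rearrangement produces no separation between the two numbers in this cell assay. Nothing measured here gives a reason for this result.

Both groups in this pair carry only a methyl on the aromatic ring, so the result says little about how the position would respond to a different kind of group. On these data alone, it remains open whether an amine or a carboxylic acid in place of that methyl, or a longer chain, would also leave the number within the scatter.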